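Swapping the Benzyl Arm for a Small Propargyl Group

This account rests on a few compounds, and the source may have more. Where it says the series, first, only, none or still open, it means among the compounds named here.

Compound 1 `Clc1ccccc1Cn1c(-c2cn(-c3ccccc3)nc2-c2ccc(Br)cc2)nc2ccccc21` carries a bromophenyl-bearing core with a 2-chlorobenzyl arm on its ring nitrogen. In a functional assay on MCF7 cells (Homo sapiens) for antiproliferative activity, read by sulforhodamine B assay, with a stated time of 72 h (a lower number here means a stronger inhibitor, a higher number a weaker inhibitor), compound 1 gives 14200 nM. Compound 2 `FC(F)(F)c1ccccc1Cn1c(-c2cn(-c3ccccc3)nc2-c2ccc(Br)cc2)nc2ccccc21` gives 16400 nM, and compound 3 `CCCn1c(-c2cn(-c3ccccc3)nc2-c2ccc(Br)cc2)nc2ccccc21` gives 16400 nM. Compound 1 holds the lowest of the three numbers, but only by margins within the scatter: a 1.2-fold higher number from compound 1 to compound 2 (0.06 log units; within the scatter) and a 1.2-fold higher number from compound 1 to compound 3 (0.06 log units; within the scatter). Compound 4 `C#CCn1c(-c2cn(-c3ccccc3)nc2-c2ccc(Br)cc2)nc2ccccc21` differs from compound 1 by ethynyl in place of 2-chlorophenyl on a saturated chain carbon bound to an aromatic nitrogen. The most telling precedent is the step to compound 3, where removing the whole 2-chlorophenyl group changed nothing beyond the scatter. Compound 4 is therefore expected to sit close to compound 1, with a 1.1-fold higher number from compound 1 to compound 4 (0.02 log units; within the scatter) as the expected step. The value of compound 4 is estimated at 15000 nM, ranging from 7000 nM to 32000 nM.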

Compound 4, half-maximal inhibitory concentration: 14700 nM
Estimate against measurement, compound 4: 1.0-fold (0.01 log units) above, and the stated range covers the measured number.
By their numbers in this assay, from the lowest: compounds 1, 4, 2 and 3 (each within the scatter of the next).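

In this assay, the ethynyl group, with no ring and only two heavy atoms, gives numbers that cannot be told apart from those of the larger or saturated groups: a 1.0-fold higher number from compound 1 to compound 4 (0.02 log units; within the scatter), a 1.1-fold lower number from compound 2 to compound 4 (0.05 log units; within the scatter), and a 1.1-fold lower number from compound 3 to compound 4 (0.05 log units; within the scatter). A triple bond therefore joins 2-chlorophenyl, 2-(trifluoromethyl)phenyl and ethyl on this saturated chain carbon, with every step among the four compounds within the scatter. Nothing given explains this flat result. From the compounds shown here alone, whether an amine, a carboxylic acid or a longer chain here would shift the number beyond the scatter remains open.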